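Swapping the Methoxyphenyl Arm: Clearance in Liver Microsomes

The compounds below may be only part of what the source reports. "The series", "measured", "known", "first", "only" and "open" are said of these compounds alone.

Measured compounds:
compound 1, `COc1ccc(-c2c(S(=O)(=O)c3ccc(C)c(F)c3)cnc3c(F)cccc23)cc1`, 3.27 mL/min
compound 2, `COc1ccc(-c2c(S(=O)(=O)c3ccc(OC)cc3)cnc3c(F)cccc23)cc1`, 2.12 mL/min
compound 3, `COc1ccc(-c2c(S(=O)(=O)c3ccc(F)cc3)cnc3c(F)cccc23)cc1`, 2.41 mL/min

These three compounds share a core and were tested in an ADME assay on microsomes from liver (Homo sapiens) for metabolic stability, tested at 2.5 uM; on this read-out lower numbers stand for slow clearance and higher numbers for fast clearance. Compound 1 gives the highest of the three numbers, yet its gaps to the others are small: a 1.5-fold lower number from compound 1 to compound 2 (0.19 log units; within the scatter) and a 1.4-fold lower number from compound 1 to compound 3 (0.13 log units; within the scatter). Between the other two, a 1.1-fold higher number from compound 2 to compound 3 (0.06 log units; within the scatter). All of these steps lie within the scatter, so the three compounds read as indistinguishable.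

Compound 4, `Cc1ccc(S(=O)(=O)c2cnc3c(F)cccc3c2-c2cccc(Cl)c2)cc1F`, has not yet been measured. It differs from compound 1 by 3-chlorophenyl in place of 4-methoxyphenyl on an aromatic carbon. Among the compounds with values here, none of the measured steps touches this position; each of them changes only the group on the sulfonyl sulfur, and each was within the scatter. There is therefore no direct evidence for the size or direction of this step. The most defensible expectation is a number close to that of compound 1, with a wide allowance either way. Compound 4 is estimated at 3 mL/min, with a range from 1.5 mL/min to 6 mL/min, which corresponds to an expected step of a 1.1-fold lower number from compound 1 to compound 4 (0.04 log units; within the scatter).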

Compound 4, intrinsic clearance in a liver preparation (reported as CLH), per the amount of preparation that the assay uses: 3.18 mL/min
Beside the measured number, compound 4's estimate is 1.1-fold (0.03 log units) below it; the range from low to high includes it.
By their numbers in this assay, from the lowest: compounds 2, 3, 4 and 1 (each within the scatter of the next).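

Within the data shown here, the steps among the earlier compounds changed only the group on the sulfonyl sulfur, whereas this one changes the other aryl arm, on the aromatic carbon opposite the ring nitrogen. In this assay, 3-chlorophenyl in place of 4-methoxyphenyl gives a 1.0-fold lower number from compound 1 to compound 4 (0.01 log units; within the scatter), so the two compounds cannot be told apart, even though the methoxy oxygen leaves and a chlorine enters at a different place on the phenyl ring. No supporting data bear on why this swap leaves the clearance reading indistinguishable.

Since the group and its place on the ring change together, 4-chlorophenyl and 3-methoxyphenyl would be needed to separate the two changes. As far as these compounds go, whether a more different group at this position, such as an amine or a carboxylic acid on the phenyl ring, would give a step beyond the scatter remains open.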